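A few compounds are considered here, and "the series" means these few. Any claim that something is new, unique, unknown or untested is made for them only; others in the source may bear on it.

Working notes on the series. The shared core of compound 3 `NC(=O)c1c(NC(=O)c2ccccc2Cl)sc2c1CCN(C(=S)Nc1ccccc1C(F)(F)F)C2` carries a thiourea with a 2-(trifluoromethyl)phenyl group. Within the data shown here, in a functional assay on MKN-74 cells (Homo sapiens) for antiproliferative activity, with a stated time of 24 h (a higher number here means a weaker inhibitor, a lower number a stronger inhibitor), compound 3 gives 1870 nM, the lowest of the three numbers so far. The nearest is compound 2 `NC(=O)c1c(NC(=O)c2ccccc2Cl)sc2c1CCN(C(=S)Nc1ccccc1F)C2`, which in this assay gives 12600 nM; the furthest is compound 1 `NC(=O)c1c(NC(=O)c2ccc(C(F)(F)F)cc2)sc2c1CCN(Cc1ccccc1F)C2`, which in this assay gives 26900 nM. Compound 1 differs from compound 3 in more than one place, so only the two values are compared.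

Compound 4 `NC(=O)c1c(NC(=O)c2ccccc2Cl)sc2c1CCN(C(=S)Nc1ccccc1-c1ccccc1)C2` is the next step: phenyl in place of trifluoromethyl on an aromatic carbon. Among the measured compounds shown here, the one measured step that bears on this position is a 6.7-fold lower number from compound 2 to compound 3 (0.83 log units; beyond the scatter), where a larger group at the same place went with a lower number. Whether a further enlargement to phenyl continues that direction is not shown by any measured pair. The expectation for compound 4 in this assay is therefore a step of a 1.2-fold lower number from compound 3 to compound 4 (0.10 log units; within the scatter), that is, a number near that of compound 3 or somewhat lower. Compound 4 is estimated at 1500 nM, with a range from 400 nM to 6000 nM.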

Compound 4, half-maximal inhibitory concentration: 25800 nM
Compound 4: the middle estimate sits 17-fold (1.24 log units) below what was measured; measured number above the stated range.
By their numbers in this assay, from the lowest: compound 3; then compound 2; then compounds 4 and 1 (each within the scatter of the next).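

Working notes, continued. In this assay the direction suggested by the step from fluoro to trifluoromethyl does not carry on to phenyl at this aromatic carbon: the change shows a 14-fold higher number from compound 3 to compound 4 (1.14 log units; beyond the scatter) and the larger group now goes with a higher number. Phenyl also stands on the weaker side of fluoro, with a 2.0-fold higher number from compound 2 to compound 4 (0.31 log units; beyond the scatter) so among compounds 2, 3 and 4 the number does not move in one direction as the group grows, and trifluoromethyl in compound 3 gives the lowest. Nothing measured in hand accounts for this reversal.

Going by these compounds, whether a methyl, a chlorine or a methoxy at this place would sit nearer compound 3 or compound 2 remains open. Also open, on these data alone, is whether the rise belongs to the aromatic ring itself, a question on which a cyclohexyl at the same place would bear.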